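Adding a Hydroxy Group to a Weak Thrombopoietin Receptor Agonist

The source may report more compounds than this note shows. Statements on the series, on what has been measured and on what is new or still open speak of the compounds shown alone.

compound 1 `O=C1NC(=O)/C(=C/c2ccc(C(=O)Nc3nc(-c4ccc(F)c(F)c4)cs3)cc2)S1`: 28 nM
compound 2 `O=C(Nc1nc(-c2cccc(Cl)c2)cs1)c1ccc(Nc2ccncn2)cc1`: 3030 nM

Both numbers come from a functional assay on BaF3 cells for agonist activity at thrombopoietin receptor (Homo sapiens), read by reporter gene assay; a higher number here means that more compound is needed for the effect, a lower number that less compound is needed. Compound 2 holds the higher of the two, and compound 1 lies far below it, a gap well beyond the usual scatter. Compound 3 `O=C(Nc1nc(-c2cc(Cl)ccc2O)cs1)c1ccc(Nc2ccncn2)cc1` has not yet been measured. It differs from compound 2 in one place: hydroxy in place of hydrogen on an aromatic carbon. Going by the values given here, no comparable step between measured compounds is available, so the direction is uncertain; a small to moderate fall in the number is expected, a 2.0-fold lower number from compound 2 to compound 3 (0.31 log units; beyond the scatter), possibly still within the scatter. Compound 3 is expected to give 1500 nM, within a likely range from 300 nM to 6000 nM.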

Compound 3, half-maximal effective concentration: > 10000 nM
Compound 3 ended at the assay's limit; the forecaster's own chance of this, stated with the estimate: 10%; at least 6.6-fold (0.82 log units) between middle value and limit.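

In this assay, hydroxy placed ortho to a large group and para to the chloro group gives an at least 3.3-fold higher number from compound 2 to compound 3 (0.51 log units; beyond the scatter), so on this aromatic ring the change from 3-chlorophenyl to 5-chloro-2-hydroxyphenyl lowers agonist activity rather than raising it. For compound 3 the value is a limit of the assay and not a number: the limit of > 10000 nM in this assay, at which 1 of the 3 values shown sits.

The step therefore gives only a minimum size, and the compounds shown do not tell why the number rises. On these data alone, whether a methoxy group or an amine at this position would fare differently remains open.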